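A few compounds are considered here, and "the series" means these few. Any claim that something is new, unique, unknown or untested is made for them only; others in the source may bear on it.

Compound 1 `CCc1ccccc1N(Cc1nnc(Cc2ccc(OC)cc2)o1)S(=O)(=O)c1ccc(C)cc1` and compound 2 `CCOc1ccc(Cc2nnc(CN(c3ccccc3CC)S(=O)(=O)c3ccc(C)cc3)o2)cc1` share one core and differ only in the alkoxy group on the benzyl ring. In an assay on CHO cells for displacement of a labelled ligand from prostaglandin E2 receptor EP1 subtype (Homo sapiens) (a lower number here means a stronger inhibitor, a higher number a weaker inhibitor), compound 1 gives 126 nM; 126 nM (2 entries), and compound 2 gives 126 nM; the two values sit within the usual scatter of each other. For the measured compounds named here, for compound 2 this is the only number available in this assay, alongside one further entry that reports no single number. Compound 3 `CCc1ccccc1N(Cc1nnc(CNc2ccc(OC)cc2)o1)S(=O)(=O)c1ccc(C)cc1` carries (4-methoxyphenyl)amino in place of 4-ethoxyphenyl on a saturated chain carbon bound to an aromatic carbon. Going by the values given here, no measured pair shows this change, so any shift is a guess. Compound 3 is expected to give 300 nM, within 80 nM to 1200 nM, a step of a 2.4-fold higher number from compound 2 to compound 3 (0.38 log units; beyond the scatter) toward weaker binding.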

Compound 3, half-maximal inhibitory concentration: 501 nM
Beside the measured number, compound 3's estimate is 1.7-fold (0.22 log units) below it; the measured number falls inside the stated range.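

For the compounds shown here, replacing 4-ethoxyphenyl with (4-methoxyphenyl)amino on this saturated chain carbon gives a 4.0-fold higher number from compound 2 to compound 3 (0.60 log units; beyond the scatter) in this assay and is the first change here to move the number beyond the scatter. The earlier pair differed only in the alkoxy group, so this shows that binding responds to a change at this position. The entering group adds a hydrogen-bond donor, but nothing measured here links that count to the step or explains the shift.

The compounds shown leave open how a longer chain or a methylated amine at this place would read in this assay and whether the weaker binding would persist.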